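The source may hold more compounds than are shown below. What is called first, only, known or untested is meant among the compounds shown, and "the series" means these compounds.

Compound 2 `C#Cc1cn([C@@H]2O[C@H](CO)[C@@H](O)[C@H]2O)c2ncnc(NC)c12` is the reference point here. In an ADME assay on BJ cells (Homo sapiens), read by MTT assay, with a stated time of 72 h (a higher number here means a weaker inhibitor, a lower number a stronger inhibitor), compound 2 gives 86000 nM, the highest of the two numbers recorded; its nearest neighbour is compound 1 `C#Cc1cn([C@@H]2O[C@H](CO)[C@@H](O)[C@H]2O)c2ncnc(C)c12`, which in this assay gives 50 nM. Compound 3 `CNc1ncnc2c1c(-c1cccs1)cn2[C@@H]1O[C@H](CO)[C@@H](O)[C@H]1O` in this assay gives > 100000 nM, which is a limit of the assay and not a number (the limit of > 100000 nM in this assay, at which 1 of the 3 values shown sits).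

The next compound, compound 4 `C#Cc1cn([C@@H]2O[C@H](CO)[C@@H](O)[C@H]2O)c2ncnc(SC)c12`, differs from compound 2 at one place: methylsulfanyl in place of methylamino on an aromatic carbon.

For the measured compounds named here, two measured steps bear on this. The step of a 1700-fold higher number from compound 1 to compound 2 (3.24 log units; beyond the scatter) shows that the methylamino group is the feature carrying the weak inhibition of compound 2 relative to the methyl of compound 1. The step of an at least 1.1-fold higher number from compound 2 to compound 3 (0.06 log units; that floor lies within the scatter), at the other substituent, is not informative because it ends at a limit (the limit of > 100000 nM in this assay, at which 1 of the 3 values shown sits). Methylsulfanyl, like methyl and unlike methylamino, carries no hydrogen-bond donor, so the expectation in this assay is a large step downward, though not necessarily the whole way back to compound 1, since only one pair defines the effect.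

Compound 4 is therefore estimated at 500 nM, with a range from 50 nM to 20000 nM, which is an expected step of a 170-fold lower number from compound 2 to compound 4 (2.24 log units; beyond the scatter).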

Compound 4, half-maximal inhibitory concentration: 68600 nM
Compound 4: middle estimate off by 140-fold (2.14 log units), on the low side; measured number above the stated range.
By their numbers in this assay, from the lowest: compound 1; then compounds 4 and 2 (each within the scatter of the next). At a limit, above all of these: compound 3.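

In this assay, replacing methylamino with methylsulfanyl on this aromatic carbon of the shared core gives no change beyond the scatter: a 1.3-fold lower number from compound 2 to compound 4 (0.10 log units; within the scatter). Methylamino has 1 hydrogen-bond donor and methylsulfanyl has 0, so donor count does not separate these two groups in this series, and the large gap to methyl is not specific to methylamino: a 1400-fold higher number from compound 1 to compound 4 (3.14 log units; beyond the scatter). With ethynyl held constant, methyl in compound 1 stands apart from both methylamino in compound 2 and methylsulfanyl in compound 4, but that contrast rests on compound 1 alone.

As far as these compounds go, whether the low number belongs to methyl alone or extends to other small groups at this position remains open, and ethyl, chlorine and an unsubstituted amine would each test this on the same core. No measurement shown here bears on what separates methyl from the other two groups.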